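Swapping a halogen on the sulfonamide aryl ring

A few compounds are considered here, and "the series" means these few. Any claim that something is new, unique, unknown or untested is made for them only; others in the source may bear on it.

Three compounds share one core. Compound 1 `COc1ccc(S(=O)(=O)Nc2c(F)cc(Br)cc2F)cc1N1CCNCC1` gives 158 nM in an assay on isolated protein for binding affinity to 5-hydroxytryptamine receptor 6 (Homo sapiens) (on this read-out higher numbers stand for weaker inhibition and lower numbers for stronger inhibition), compound 2 `COc1ccc(S(=O)(=O)Nc2cc(Cl)cc(Cl)c2Br)cc1N1CCNCC1` gives 3.16 nM, and compound 3 `COc1ccc(S(=O)(=O)Nc2cc(Br)cc(Cl)c2Cl)cc1N1CCNCC1` gives 3.98 nM. Compound 3 stands second highest of the three, with a 1.3-fold higher number from compound 2 to compound 3 (0.10 log units; within the scatter) and a 40-fold lower number from compound 1 to compound 3 (1.60 log units; beyond the scatter). Compound 4 `COc1ccc(S(=O)(=O)Nc2cc(Br)cc(F)c2Cl)cc1N1CCNCC1` differs from compound 3 by fluoro in place of chloro on an aromatic carbon, the fluoro sitting ortho to a chloro group and meta to a bromo group. Within the data shown here, no measured step isolates this swap: the large steps of a 50-fold lower number from compound 1 to compound 2 (1.70 log units; beyond the scatter) and a 40-fold lower number from compound 1 to compound 3 (1.60 log units; beyond the scatter) each change several halogens at once, while the rearrangement in a 1.3-fold higher number from compound 2 to compound 3 (0.10 log units; within the scatter) stayed within the scatter. He therefore expects for compound 4 a step of a 1.3-fold higher number from compound 3 to compound 4 (0.10 log units; within the scatter) that stays within the scatter, and estimates 5 nM, within 2 nM to 15 nM.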

Compound 4, inhibition constant: 3.16 nM
Estimate against measurement, compound 4: 1.6-fold (0.20 log units) above; measured number inside the range.
By their numbers in this assay, from the lowest: compounds 2, 4 and 3 (each within the scatter of the next); then compound 1.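

Among these compounds, this step isolates the swap for the first time: in this assay, fluoro in place of chloro on this aromatic carbon stays within the scatter (a 1.3-fold lower number from compound 3 to compound 4 (0.10 log units; within the scatter)), so either halogen is accepted here. The 5-bromo-2-chloro-3-fluorophenyl group also cannot be told apart from the 2-bromo-3,5-dichlorophenyl group (no change at the digits printed from compound 2 to compound 4 (within the scatter)), and it keeps the large gain over the 4-bromo-2,6-difluorophenyl group (a 50-fold lower number from compound 1 to compound 4 (1.70 log units; beyond the scatter)). No available measurement bears on the reason. From the compounds shown here alone, whether a hydrogen, a methoxy group or a nitrile on this carbon would hold the number stays open.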